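The source may hold more compounds than are shown below. What is called first, only, known or untested is meant among the compounds shown, and "the series" means these compounds.

Compound 1 `O=C1C(=O)N(CC(CO)NCCCNc2ccnc3cc(Cl)ccc23)c2ccccc21` was tested in an ADME assay on HCT-116 cells (Homo sapiens) for cytotoxicity, read by MTT assay, with a stated time of 48 h, tested at 2 uM (on this read-out lower numbers stand for a weaker effect and higher numbers for a stronger effect at the one concentration tested), alongside two related compounds. In this assay compound 1 gives -12%, the lowest of the three numbers. Compound 2 `O=C1C(=O)N(CC(CO)NCCNc2ccnc3cc(Cl)ccc23)c2ccc(Cl)cc21` gives -11%, which lies within the scatter of the number for compound 1. Compound 3 `O=C1C(=O)N(CC(CO)NCCCCNc2ccnc3cc(Cl)ccc23)c2ccc(F)cc21` gives 0%, a number that stands beyond the scatter above compound 1. Compound 4 `O=C1C(=O)N(CC(CO)NCCCNc2ccnc3cc(Cl)ccc23)c2ccc(F)cc21` has not yet been measured in this assay. It differs from compound 1 in a single place: fluoro in place of hydrogen on an aromatic carbon. Within the data shown here, no measured pair shows this change on its own, so its size cannot be read from the data. In this assay the expected step is a number 7 percentage points higher from compound 1 to compound 4 (within the scatter), small and not beyond the scatter. Compound 4 is therefore estimated at -5%, within a range from -20% to 10%.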

Compound 4, a percentage reported as inhibition, at one concentration (the size of the read-out at that concentration, not a potency): 12%
Compound 4: the middle estimate sits 17 percentage points below what was measured, outside the stated range (above it).
By their numbers in this assay, from the lowest: compounds 1 and 2 (each within the scatter of the next); then compound 3; then compound 4.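

In this assay, fluoro in place of hydrogen on an aromatic carbon, at the place meta to a fused ring and para to a fused ring, gives a number 24 percentage points higher from compound 1 to compound 4 (beyond the scatter) for this single change. Among these compounds, this position therefore responds to one added fluoro atom, which the earlier compounds could not show because none isolated the change. Nothing measured here accounts for the step. On these data alone, whether a methoxy or trifluoromethyl group at this position would give a similar step remains open. So does whether fluoro would act alike with a shorter or longer chain.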